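The source may report more compounds than this note shows. Statements on the series, on what has been measured and on what is new or still open speak of the compounds shown alone.

Measured compounds and values in a functional assay (Sus scrofa) with sulfonylurea receptors; K-ATP channels (Homo sapiens) as the target; a lower number here means a smaller maximal response, a higher number a larger maximal response:

compound 1 `O=C(Nc1c(C(O)(C(F)(F)F)C(F)(F)F)ccc2ccccc12)C1CC1`: 100%
compound 2 `O=C(Nc1c(C(O)(C(F)(F)F)C(F)(F)F)ccc2ccccc12)c1cccc(Cl)c1`: 84%
compound 3 `Cc1cccc(C(=O)Nc2c(C(O)(C(F)(F)F)C(F)(F)F)ccc3ccccc23)c1`: 97%

Compound 3 stands second highest of the three numbers. Its nearest neighbour is compound 1, and the step of a number 3 percentage points lower from compound 1 to compound 3 (within the scatter) lies within the scatter, so the two cannot be ordered. The furthest is compound 2, and the step of a number 13 percentage points higher from compound 2 to compound 3 (beyond the scatter) is beyond the scatter, though modest. The other step, a number 16 percentage points lower from compound 1 to compound 2 (beyond the scatter), is likewise modest.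

Compound 4 `N#Cc1cccc(C(=O)Nc2c(C(O)(C(F)(F)F)C(F)(F)F)ccc3ccccc23)c1` has not yet been measured. Its difference from compound 3: cyano in place of methyl on an aromatic carbon. For the measured compounds named here, the one measured step at the same place, a number 13 percentage points higher from compound 2 to compound 3 (beyond the scatter), shows that exchanging the group on that aromatic carbon moves the maximal response only modestly, and the steps from compound 1 show that the whole set so far sits within a narrow band. A step of about the same size as that one, in the downward direction or none beyond the scatter, is therefore expected for a number 8 percentage points lower from compound 3 to compound 4 (within the scatter).

Compound 4 is estimated to give 89%, with a range from 76% to 100%.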

Compound 4, largest response reached (reported as efficacy), in percent of the reference or control that the assay uses: 96%
Compound 4: middle estimate off by 7 percentage points, on the low side, within the range that was stated.
By their numbers in this assay, from the lowest: compound 2; then compounds 4, 3 and 1 (each within the scatter of the next).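

In this assay, cyano in place of methyl on this aromatic carbon gives a number 1 percentage points lower from compound 3 to compound 4 (within the scatter) and so leaves the maximal response unresolved, which adds a nitrile to the groups tolerated at this position without a readable change. Cyano in place of chloro at the same carbon gives a number 12 percentage points higher from compound 2 to compound 4 (beyond the scatter) and is beyond the scatter but modest, so among the three groups on this carbon compound 2, with chloro, is the one that stands apart, while the methyl and cyano compounds cannot be ordered. On the carbonyl carbon, 3-cyanophenyl in place of cyclopropyl gives a number 4 percentage points lower from compound 1 to compound 4 (within the scatter) and so cannot be told from the cyclopropyl amide, whereas 3-chlorophenyl could be.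

No measurement on hand accounts for chloro alone standing apart from methyl and cyano. Still open, from the compounds shown here alone, is whether an amine or a carboxylic acid on this aromatic carbon, or a longer chain in place of cyclopropyl on the carbonyl carbon, would take the maximal response outside the narrow band seen so far.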